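A Hydrazone Aryl Swap on a Shared Core

The source may report more compounds than this note shows. Statements on the series, on what has been measured and on what is new or still open speak of the compounds shown alone.

Compound 1 `Cn1c(=O)c(=O)n(C2CCCC2)c2nc(N/N=C/c3ccco3)ncc21`: > 100000 nM
Compound 2 `COc1ccc(/C=N/Nc2ncc3c(n2)n(C2CCCC2)c(=O)c(=O)n3C)cc1`: > 100000 nM
Compound 3 `Cn1c(=O)c(=O)n(C2CCCC2)c2nc(N/N=C/c3ccccc3F)ncc21`: 31200 nM

In a functional assay on A549 cells (Homo sapiens) for antiproliferative activity, read by MTT assay (a lower number here means a stronger inhibitor, a higher number a weaker inhibitor), compound 1 gives > 100000 nM, a limit of the assay rather than a number. Compound 2 likewise gives > 100000 nM, again only a limit. Among the measured compounds shown here, compound 3 gives 31200 nM, the single real number in the set. Compound 1 therefore stands at the limit of > 100000 nM in this assay, at which 2 of the 3 values shown sit. The step from compound 1 to compound 2 is a step that the two limits leave unreadable from compound 1 to compound 2. The step to compound 3 is an at least 3.2-fold lower number from compound 1 to compound 3 (0.50 log units; beyond the scatter), and an at least 3.2-fold lower number from compound 2 to compound 3 (0.50 log units; beyond the scatter) says the same of the change from the 4-methoxyphenyl compound.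

Compound 4 `CSc1ccc(/C=N/Nc2ncc3c(n2)n(C2CCCC2)c(=O)c(=O)n3C)cc1` differs from compound 1 by 4-(methylsulfanyl)phenyl in place of furan-2-yl on a carbon with a double bond to nitrogen. For the measured compounds named here, of the measured steps, the one from compound 1 to compound 2 bears most closely on this change, since 4-methoxyphenyl and 4-(methylsulfanyl)phenyl are both six-membered aromatic rings of carbon only bearing one hydrogen-bond acceptor, and that step was unreadable because both ends sit at the limit (the limit of > 100000 nM in this assay, at which 2 of the 3 values shown sit). The step from compound 1 to compound 4 is therefore expected to be a number no higher from compound 1 to compound 4 (the limit leaves the size open), that is, none beyond the scatter. Compound 4 is estimated at 100000 nM, within a range from 30000 nM to 300000 nM, and most probably reported only as a limit.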

Compound 4, half-maximal inhibitory concentration: 14100 nM
Beside the measured number, compound 4's estimate is 7.1-fold (0.85 log units) above it; the whole stated range lies above it.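

In this assay, the change at this carbon now has a clear effect on the number: the swap of furan-2-yl for 4-(methylsulfanyl)phenyl gives an at least 7.0-fold lower number from compound 1 to compound 4 (0.85 log units; beyond the scatter), and the exchange of methoxy for methylsulfanyl on an aromatic carbon gives an at least 7.0-fold lower number from compound 2 to compound 4 (0.85 log units; beyond the scatter). Among the compounds shown here, the new compound also improves on the only earlier compound with a real number, with a 2.2-fold lower number from compound 3 to compound 4 (0.34 log units; beyond the scatter), which makes compound 4 the most potent of the four, so a six-membered aromatic ring at this carbon can give a low or a high number depending on what it carries. Compound 1 and compound 2 each stand at a limit, so the two steps from them fix only a minimum size: the limit of > 100000 nM in this assay, at which 2 of the 4 values shown sit.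

From the compounds shown here alone, the true size of those two steps remains open, and the step between compound 1 and compound 2 still cannot be read. Also open, going by these compounds, is whether a 4-aminophenyl or a 4-carboxyphenyl group on this carbon would lower the number further or return it to the limit.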